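Fluorine position on the aryl group of compound 3

The compounds below may be only part of what the source reports. "The series", "measured", "known", "first", "only" and "open" are said of these compounds alone.

Working notes on the series. In a functional assay on CHO cells for agonist activity at Free fatty acid receptor 1 (Homo sapiens), read by FLIPR and calcium flux, tested at 100 nM (a lower number here means a weaker effect, a higher number a stronger effect of the compound at the concentration tested), compound 1 `Cc1nc(-c2cc3ccccc3o2)sc1COc1ccc2c(c1)OCC2CC(=O)O` gives 14.8%, compound 2 `Cc1ccc(-c2nc(C)c(COc3ccc4c(c3)OCC4CC(=O)O)s2)cc1` gives 54.9%, and compound 3 `Cc1nc(-c2ccccc2F)sc1COc1ccc2c(c1)OCC2CC(=O)O` gives 25.8%. Compound 3 thus stands second highest of the three numbers: it lies a number 11 percentage points higher from compound 1 to compound 3 (beyond the scatter) and a number 29.1 percentage points lower from compound 2 to compound 3 (beyond the scatter).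

Compound 4 `Cc1nc(-c2cccc(F)c2)sc1COc1ccc2c(c1)OCC2CC(=O)O` is the unmeasured partner of compound 3; the change is 3-fluorophenyl in place of 2-fluorophenyl on an aromatic carbon.

Within the data shown here, no measured step moves the fluorine within the same aryl ring. The steps that exist replace the whole group: a number 40.1 percentage points higher from compound 1 to compound 2 (beyond the scatter), a number 11 percentage points higher from compound 1 to compound 3 (beyond the scatter) and a number 29.1 percentage points lower from compound 2 to compound 3 (beyond the scatter). These show that the aryl group as a whole matters, but give no reading on the position of a single fluorine. The expectation for compound 4 is therefore a step of a number 4.2 percentage points higher from compound 3 to compound 4 (within the scatter) in this assay, likely within the scatter, with direction undecided. Compound 4 is estimated at 30% in this assay, within a range of 12% to 50%.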

Compound 4, a percentage reported as activity, at one concentration (the size of the read-out at that concentration, not a potency): 56.9%
Beside the measured number, compound 4's estimate is 26.9 percentage points below it, outside the stated range (above it).
By their numbers in this assay, from the lowest: compound 1; then compound 3; then compounds 2 and 4 (each within the scatter of the next).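

Moving the single fluorine, with the atom count unchanged, gives a number 31.1 percentage points higher from compound 3 to compound 4 (beyond the scatter) in this assay, so the placement of the fluorine on the phenyl ring carried by the five-membered aromatic ring matters in its own right, and not only the identity of the whole aryl group. The 3-fluorophenyl group also reads level with 4-methylphenyl, at a number 2 percentage points higher from compound 2 to compound 4 (within the scatter), and well clear of 1-benzofuran-2-yl, at a number 42.1 percentage points higher from compound 1 to compound 4 (beyond the scatter). Nothing available accounts for the effect of the fluorine's placement.

Open, as far as these compounds go, is how 4-fluorophenyl would compare with the two fluorinated isomers, and whether a larger group such as 3-chlorophenyl or 3-methoxyphenyl would hold the level of compound 4. These are readings at one concentration, so they do not separate potency from the size of the maximal response.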